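Trading a Hydroxy for Benzylamino at the Carbonyl

The source may hold more compounds than are shown below. What is called first, only, known or untested is meant among the compounds shown, and "the series" means these compounds.

Compound 1 `OB1OCc2ccc(-n3cccc3Sc3ccccc3Cl)cc21` gives > 10 ug/mL in an ADME assay on L929 cells (Mus musculus) for cytotoxicity, read by resazurin assay, with a stated time of 72 h; a lower number here means a stronger inhibitor, a higher number a weaker inhibitor. Compound 2 `O=C(O)c1cccn1-c1ccc2c(c1)B(O)OC2` gives > 10 ug/mL in this assay.

For compound 1 this value is a limit of the assay, not a number. For compound 2 it is likewise a limit of the assay. Compound 2 therefore stands at the highest point the data reach, and it shares that point with every other value shown, since (the limit of > 10 ug/mL in this assay, at which 2 of the 2 values shown sit). Compound 3 `O=C(NCc1ccccc1)c1cccn1-c1ccc2c(c1)B(O)OC2` has not been measured yet. It differs from compound 2 in one place: benzylamino in place of hydroxy on a carbonyl carbon. For the measured compounds named here, no pair of measured compounds offers a comparable change, so the size of this step cannot be read from a measured example. With both measured compounds resting at the limit, no movement beyond the usual scatter is expected in this assay, and the most likely outcome is again a limit. Compound 3 is therefore estimated at 15 ug/mL, within 5 ug/mL to 40 ug/mL, which means an expected step that the limit leaves unreadable from compound 2 to compound 3.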

Compound 3, half-maximal inhibitory concentration: > 10 ug/mL
Compound 3: a limit, no number (the forecaster's own chance of this, stated with the estimate: 65%); the middle value lies beyond the limit too.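

No step can be read between compound 2 and compound 3, since both results in this assay are limits and not numbers: (the limit of > 10 ug/mL in this assay, at which 3 of the 3 values shown sit). The compounds shown leave open where their true values lie, and whether benzylamino in place of hydroxy on a carbonyl carbon changes anything.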